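The source may hold more compounds than are shown below. What is called first, only, known or untested is meant among the compounds shown, and "the series" means these compounds.

Measured in a functional assay on K562 cells (Homo sapiens) for antiproliferative activity, read by MTT assay; a lower number here means a stronger inhibitor, a higher number a weaker inhibitor:
- Compound 1 `CC(C)COC(=O)N1CCCc2cc(S(=O)(=O)N3CC(c4ccccc4)NC3=O)ccc21` gives 2380 nM
- Compound 2 `CCCCOC(=O)N1CCCc2cc(S(=O)(=O)N3CC(c4ccccc4)NC3=O)ccc21` gives 3680 nM
- Compound 3 `O=C(c1ccccc1)N1CCCc2cc(S(=O)(=O)N3CC(c4ccccc4)NC3=O)ccc21` gives 1220 nM

Compound 3 cannot be told apart from compound 1, as the step of a 2.0-fold lower number from compound 1 to compound 3 (0.29 log units; within the scatter) stays inside the usual scatter of repeated measurements. It stands clearly apart only from compound 2, and that step, a 3.0-fold lower number from compound 2 to compound 3 (0.48 log units; beyond the scatter), is modest.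

Compound 4 `O=C(CCl)NC(=O)N1CCCc2cc(S(=O)(=O)N3CC(c4ccccc4)NC3=O)ccc21` keeps the shared core of compound 3 and changes one group: ((chloromethyl)carbonyl)amino in place of phenyl on a carbonyl carbon.

The two steps to compound 3 bear most directly on this, since each swaps the group on that same carbonyl carbon. Neither was large, and swapping the chain of compound 1 for that of compound 2 gave only a 1.5-fold higher number from compound 1 to compound 2 (0.19 log units; within the scatter). Within the data shown here, none of the measured compounds carries the entering group, however, so the data give no direction for this change. Going by the small size of the steps from compound 1 and compound 2, no step beyond the scatter is expected. The expected step is a 1.2-fold higher number from compound 3 to compound 4 (0.09 log units; within the scatter). Compound 4 is estimated at 1500 nM, with an expected range from 450 nM to 4500 nM.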

Compound 4, half-maximal inhibitory concentration: 515 nM
Compound 4: middle estimate off by 2.9-fold (0.46 log units), on the high side; low and high end bracket the measured number.
By their numbers in this assay, from the lowest: compound 4; then compounds 3, 1 and 2 (each within the scatter of the next, the first and the last beyond it).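

In this assay, the carbonyl carbon bound to the ring's amide-type nitrogen turns out not to need a phenyl ring or an alkoxy chain for a low number: ((chloromethyl)carbonyl)amino, which has no ring, gives a step beyond the scatter when it replaces phenyl (a 2.4-fold lower number from compound 3 to compound 4 (0.37 log units; beyond the scatter)). The same group replacing butoxy (a 7.1-fold lower number from compound 2 to compound 4 (0.85 log units; beyond the scatter)) or isobutoxy (a 4.6-fold lower number from compound 1 to compound 4 (0.66 log units; beyond the scatter)) gives the two widest steps in this set. Among these compounds, compound 4 therefore has the lowest number of the four, and this position can shift the number further than the earlier compounds showed, since their only step beyond the scatter was the modest one from butoxy to phenyl.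

No measurement here offers a cause for this shift, and the entering group differs from phenyl in several ways at once, so the compounds do not show which part of it matters. Going by these compounds, it also stays open how acetylamino, the same group with methyl in place of chloromethyl, would compare on that carbonyl carbon, and whether the chlorine contributes to the step at all.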